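Amine ring swap at the chain end: stability outlook

A few compounds are considered here, and "the series" means these few. Any claim that something is new, unique, unknown or untested is made for them only; others in the source may bear on it.

Series notes. Compound 1 `Cc1ccccc1-c1nc(CN2CCC(C(=O)NCCCN3CC(C)(C)CC(C)(C)C3)CC2)c(C)o1` is the reference point here. In an ADME assay on microsomes from liver (Rattus norvegicus) for metabolic stability, read by LC-MS, using NADPH, at 37 degrees C (on this read-out higher numbers stand for a longer-lived compound and lower numbers for a shorter-lived compound), compound 1 gives 0.095 h, the lowest of the two numbers available. Compound 2 `Cc1oc(-c2ccc(F)cc2)nc1CN1CCC(C(=O)NCCCN2C[C@H](C)C[C@H](C)C2)CC1` is its nearest neighbour; in this assay compound 2 gives 0.468 h, a higher number than compound 1, and that gap lies beyond the scatter. The two differ in more than one place, so no single step can be read from them.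

Compound 3 `Cc1ccccc1-c1nc(CN2CCC(C(=O)NCCCN3CC4CCCC(C4)C3)CC2)c(C)o1` is not yet measured. It differs from compound 1 as follows: a group of 9 heavy atoms (8 carbon, 1 nitrogen; one six-membered non-aromatic ring of carbon only, one six-membered non-aromatic ring with 1 hetero atom) in place of a group of 10 heavy atoms (9 carbon, 1 nitrogen; one six-membered non-aromatic ring with 1 hetero atom), on a saturated chain carbon, three bonds along the chain from an amide-type nitrogen. Among the compounds with values here, no measured step of this kind exists in the set, and compound 2 does not isolate it. The step is expected to be small, a 1.3-fold higher number from compound 1 to compound 3 (0.10 log units; within the scatter), with no clear direction beyond the scatter. Compound 3 is therefore expected to give 0.12 h in this assay, within a range from 0.05 h to 0.3 h.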

Compound 3, half-life: 0.123 h
Compound 3: middle estimate off by 1.0-fold (0.01 log units), on the low side; low and high end bracket the measured number.
By their numbers in this assay, from the lowest: compounds 1 and 3 (each within the scatter of the next); then compound 2.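

In this assay the first step readable at this position (a 1.3-fold higher number from compound 1 to compound 3 (0.11 log units; within the scatter)) lies within the scatter. On this read-out, the group of 9 heavy atoms with two six-membered rings therefore cannot be told apart from the group of 10 heavy atoms with one six-membered ring, on a saturated chain carbon, three bonds along the chain from an amide-type nitrogen. No supporting evidence bears on this result.

The compounds shown leave open whether a morpholine ring or a piperazine ring in this place would shift the half-life beyond the scatter. They also leave open whether the same swap would give a similarly small step on the core of compound 2, which differs from compound 1 in more than one place.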